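Methyl in place of nitro on the aryl of compound 3

The source may report more compounds than this note shows. Statements on the series, on what has been measured and on what is new or still open speak of the compounds shown alone.

In a functional assay on cells (Cancer cell lines, Homo sapiens) for inhibition, read by MTT assay, with a stated time of 48 h (a lower number here means a stronger inhibitor, a higher number a weaker inhibitor), compound 1 `Cc1ccc(/C=C/C(=O)NNC(=O)c2ccc3c(c2)OCCO3)cc1` gives 1050 nM, compound 2 `O=C(/C=C/c1cccc(Cl)c1)NNC(=O)c1ccc2c(c1)OCCO2` gives 3560 nM, and compound 3 `O=C(/C=C/c1ccccc1[N+](=O)[O-])NNC(=O)c1ccc2c(c1)OCCO2` gives 890 nM. Compound 3 has the lowest of the three numbers, but its gap to compound 1 is within the scatter, as a 1.2-fold lower number from compound 1 to compound 3 (0.07 log units; within the scatter) shows; only compound 2 stands apart, with a 3.4-fold higher number from compound 1 to compound 2 (0.53 log units; beyond the scatter) and a 4.0-fold lower number from compound 2 to compound 3 (0.60 log units; beyond the scatter) both beyond the scatter.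

Compound 4 `Cc1ccccc1/C=C/C(=O)NNC(=O)c1ccc2c(c1)OCCO2` differs from compound 3 in one place: methyl in place of nitro on an aromatic carbon. Going by the values given here, no measured step changes this group at this position alone. The nearest guide is compound 1 against compound 3, where a methylphenyl and a nitrophenyl sit within the scatter of each other; the two steps involving compound 2 concern a chlorophenyl and bear only loosely on it.

The step to compound 4 is therefore expected to be a 1.2-fold higher number from compound 3 to compound 4 (0.09 log units; within the scatter), nothing beyond the scatter. For compound 4 the estimate in this assay is 1100 nM, with a range from 450 nM to 2800 nM.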

Compound 4, half-maximal inhibitory concentration: 7710 nM
For compound 4 the middle estimate is 7.0-fold (0.85 log units) below the measured one, and the stated range ends below it.
By their numbers in this assay, from the lowest: compounds 3 and 1 (each within the scatter of the next); then compound 2; then compound 4.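

In this assay, going by these compounds alone, swapping nitro for methyl on this aromatic carbon is far from neutral, with an 8.7-fold higher number from compound 3 to compound 4 (0.94 log units; beyond the scatter) as the largest step so far, so the closeness of compound 1 and compound 3 does not extend to a methyl at this position. Where the methyl sits also matters, with a 7.3-fold higher number from compound 1 to compound 4 (0.87 log units; beyond the scatter) for 2-methylphenyl in place of 4-methylphenyl, and the 2-methylphenyl compound also falls behind the 3-chlorophenyl compound, with a 2.2-fold higher number from compound 2 to compound 4 (0.34 log units; beyond the scatter) on that comparison. Nothing available here accounts for these steps.

On these data alone, it remains open whether another group on this aromatic carbon, such as an amine, a methoxy group or a chlorine, would stay close to compound 3 or move towards compound 4. Also open, as far as these compounds go, is whether a 4-nitrophenyl group would match 2-nitrophenyl, which would show whether the position matters for nitro as it does for methyl.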